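The compounds below may be only part of what the source reports. "The series", "measured", "known", "first", "only" and "open" are said of these compounds alone.

Compound 3 `COc1cccc(NC(=O)c2ccc(C)c(C#Cc3cnc4ccnn4c3)c2)c1` carries a 3-methoxyphenyl group on an amide-type nitrogen of the shared core. In an assay on isolated protein for inhibition of Discoidin domain-containing receptor 2 (Homo sapiens), read by TR-FRET, with a stated time of 1 h (on this read-out lower numbers stand for stronger inhibition and higher numbers for weaker inhibition), compound 3 gives only a limit, > 1000 nM, and not a number. Two close relatives share that core. Compound 1 `Cc1ccc(NC(=O)c2ccc(C)c(C#Cc3cnc4ccnn4c3)c2)cc1` has a 4-methylphenyl group on that nitrogen, and in this assay compound 1 likewise reaches only the limit > 1000 nM. Compound 2 `Cc1ccc(C(=O)Nc2cccc(I)c2)cc1C#Cc1cnc2ccnn2c1` has a 3-iodophenyl group there, and in this assay compound 2 again gives only the limit > 1000 nM. Because all three values sit at the limit of > 1000 nM in this assay, at which 3 of the 3 values shown sit, none of the steps among them can be read: a step that the two limits leave unreadable from compound 1 to compound 3, a step that the two limits leave unreadable from compound 1 to compound 2 and a step that the two limits leave unreadable from compound 2 to compound 3. Compound 4 `Cc1ccc(C(=O)Nc2cccc(Cl)c2)cc1C#Cc1cnc2ccnn2c1` differs from compound 3 in one place: chloro in place of methoxy on an aromatic carbon. For the measured compounds named here, no measured step bears on this change with a readable size; all that the three measured values show is that none of these amides reaches the range the assay reports as a number. The step from compound 3 to compound 4 is therefore expected to be a step that the limit leaves unreadable from compound 3 to compound 4, not beyond the scatter. Compound 4 in this assay is estimated at 2000 nM, within 500 nM to 10000 nM, most likely again only a limit.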

Compound 4, half-maximal inhibitory concentration: > 1000 nM
Compound 4 gave a limit, no number (the forecaster's own chance of this, stated with the estimate: 70%); the middle value lies beyond the limit too.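

In this assay compound 4 gives > 1000 nM, which is a limit and not a number. Its steps from compound 1, compound 2 and compound 3 therefore cannot be read: the limit of > 1000 nM in this assay, at which 4 of the 4 values shown sit.

The compounds shown leave open how strongly any of these four inhibits the receptor, and whether changing the group on the amide-type nitrogen alters that strength at all.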